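This account rests on a few compounds, and the source may have more. Where it says the series, first, only, none or still open, it means among the compounds named here.

In a functional assay on Caco-2 cells (Homo sapiens) for activation, read by fluorescence, tested at 10 uM (on this read-out lower numbers stand for a stronger effect and higher numbers for a weaker effect at the one concentration tested), compound 1 `COc1cc(/C=C/C2=CC(=O)CC(c3ccc(O)c(OC)c3)N2CCCO)ccc1O` gives 91%, compound 2 `COCCCN1C(/C=C/c2ccc(O)cc2)=CC(=O)CC1c1ccc(O)cc1` gives 99.4%, and compound 3 `O=C(/C=C(/C=C/c1ccc(O)cc1)NCCCO)/C=C/c1ccc(O)cc1` gives 91.7%. The three numbers lie close together: the gap from compound 3 to compound 1 and the gap from compound 3 to compound 2 both fall within the usual scatter of this kind of measurement, so none of the three can be told apart. Compound 4 `COCCNC(=C\C(=O)/C=C/c1ccc(O)cc1)/C=C/c1ccc(O)cc1` has the same atoms as compound 3, joined differently: methoxy in place of hydroxymethyl on a saturated chain carbon, two bonds along the chain from an amine nitrogen. Within the data shown here, no pair of measured compounds differs in one place only, so nothing shows how such a change moves this assay. Because compound 3 gives 91.7% and its neighbours give similar numbers, the expected step is a number 1.3 percentage points higher from compound 3 to compound 4 (within the scatter), no change beyond the scatter. Compound 4 is estimated at 93%, within 80% to 105%.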

Compound 4, a percentage reported as activity, at one concentration (the size of the read-out at that concentration, not a potency): 89.7%
For compound 4 the middle estimate is 3.3 percentage points above the measured one, within the range that was stated.
By their numbers in this assay, from the lowest: compounds 4, 1, 3 and 2 (each within the scatter of the next).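

Among these compounds, this is the first pair that differs in one place only: in this assay, methoxy in place of hydroxymethyl on a saturated chain carbon, two bonds along the chain from an amine nitrogen, gives a number 2 percentage points lower from compound 3 to compound 4 (within the scatter). The swap takes away a hydrogen-bond donor and keeps the atoms the same, yet the two compounds cannot be told apart at this position. Nothing measured here bears on why. On these data alone, whether a carboxylic acid or an amine at the end of this chain, or a longer chain, would give a step beyond the scatter remains open.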